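Swapping the Dichlorophenyl Ring on the Carbonyl Carbon

A few compounds are considered here, and "the series" means these few. Any claim that something is new, unique, unknown or untested is made for them only; others in the source may bear on it.

Of the compounds shown here, three built on one shared core have been tested in a functional assay on HepG2 cells (Homo sapiens) for antiproliferative activity, read by MTT assay, with a stated time of 48 h; on this read-out lower numbers stand for stronger inhibition and higher numbers for weaker inhibition. Compound 1 `CCCCCCOc1ccc(C(=O)/C=C/c2c(/C=C/c3ccc(OC)cc3)cc(OC)cc2OC)cc1` gives 16.2 ug/mL. Compound 2 `COc1ccc(/C=C/c2cc(OC)cc(OC)c2/C=C/C(=O)c2ccc(Cl)c(Cl)c2)cc1` gives 10.8 ug/mL. Compound 3 `COc1ccc(/C=C/c2cc(OC)cc(OC)c2/C=C/C(=O)c2ccc(N)cc2)cc1` gives 7.5 ug/mL. Among these three numbers compound 2 stands second highest; its nearest neighbour is compound 3 and its furthest is compound 1, yet both gaps from compound 2 lie within the usual scatter, so compound 2 cannot be set apart from either.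

Compound 4 `COc1ccc(/C=C/c2cc(OC)cc(OC)c2/C=C/C(=O)c2ccc(Br)cc2)cc1` has not yet been measured. It differs from compound 2 in one place: 4-bromophenyl in place of 3,4-dichlorophenyl on a carbonyl carbon. Going by the values given here, only one measured step touches this carbonyl carbon, and that step was a 1.4-fold lower number from compound 2 to compound 3 (0.16 log units; within the scatter), within the scatter. Among the compounds with values here, the one step beyond the scatter, a 2.2-fold lower number from compound 1 to compound 3 (0.33 log units; beyond the scatter), concerns a different change, amino in place of hexyloxy on an aromatic carbon, and both of these steps bring in an amino group, which the change to compound 4 does not. Within the data shown here, no measured step exchanges one ring for another without that group, so the expectation rests on the within-scatter step alone.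

Compound 4 is therefore expected to show no step beyond the scatter, a 1.1-fold higher number from compound 2 to compound 4 (0.03 log units; within the scatter), in this assay. The estimate for compound 4 is 11.5 ug/mL, with a range from 5.5 ug/mL to 24 ug/mL.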

Compound 4, half-maximal inhibitory concentration: 12.9 ug/mL
Compound 4: the middle estimate sits 1.1-fold (0.05 log units) below what was measured; low and high end bracket the measured number.
By their numbers in this assay, from the lowest: compounds 3, 2, 4 and 1 (each within the scatter of the next, the first and the last beyond it).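

In this assay, the 4-bromophenyl ring replaces the 3,4-dichlorophenyl ring on the carbonyl carbon with a 1.2-fold higher number from compound 2 to compound 4 (0.08 log units; within the scatter) and brings no amino group, so one halogen-bearing ring gave way to another at this position without a readable shift. The other two comparisons, a 1.7-fold higher number from compound 3 to compound 4 (0.24 log units; within the scatter) and a 1.3-fold lower number from compound 1 to compound 4 (0.10 log units; within the scatter), show that compound 4 cannot be set apart from either compound 3 or compound 1, even though those two are set apart from each other by a small margin. No accompanying measurement offers an explanation for these numbers.

As far as these compounds go, all four compounds differ only in the ring on the carbonyl carbon, and each of these rings carries a halogen, an amino group or hexyloxy, so the rest of the shared core remains untested here. Whether a ring bearing a carboxylic acid or a longer amine chain on the carbonyl carbon would move the number beyond the usual scatter in either direction remains an open question.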